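A New Amine End on the Chain

The source may hold more compounds than are shown below. What is called first, only, known or untested is meant among the compounds shown, and "the series" means these compounds.

Compound 1 `CCNCCCOc1ccc2cc(NC(=O)c3ccc(O)c(CC=C(C)C)c3)c(=O)oc2c1C`: 720 nM
Compound 2 `CC(C)=CCc1cc(C(=O)Nc2cc3ccc(OCCCN(C)C(C)C)c(C)c3oc2=O)ccc1O`: 570 nM

Going by the values given here, both values come from a functional assay on SK-BR-3 cells (Homo sapiens) for antiproliferative activity (a lower number here means a stronger inhibitor, a higher number a weaker inhibitor), and compound 2 stands level with the only other measured compound, within the scatter. Compound 3 `CC(C)=CCc1cc(C(=O)Nc2cc3ccc(OCCCNCC(N)=O)c(C)c3oc2=O)ccc1O` keeps the shared core and alters only the end of the chain: (carbamoylmethyl)amino in place of isopropyl(methyl)amino on a saturated chain carbon, three bonds along the chain from an oxygen on an aromatic ring. In words, this is (carbamoylmethyl)amino in place of isopropyl(methyl)amino on a saturated chain carbon, three bonds along the chain from an oxygen on an aromatic ring. Among the compounds with values here, one measured step bears on this place: a 1.3-fold lower number from compound 1 to compound 2 (0.10 log units; within the scatter). Within the data shown here, that step exchanged a different pair of amines, and no measured compound carries the carbamoyl group, so the evidence is thin. No change beyond the scatter is therefore expected in this assay. The expected step is a 1.4-fold higher number from compound 2 to compound 3 (0.15 log units; within the scatter). For compound 3 the estimate is 800 nM, with an expected range of 300 nM to 2200 nM.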

Compound 3, half-maximal inhibitory concentration: 2290 nM
Estimate against measurement, compound 3: 2.9-fold (0.46 log units) below; the whole stated range lies below it.
By their numbers in this assay, from the lowest: compounds 2 and 1 (each within the scatter of the next); then compound 3.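

In this assay the end of the chain proves not to be indifferent: the earlier exchange between two amines stayed within the scatter, whereas (carbamoylmethyl)amino brings a 4.0-fold higher number from compound 2 to compound 3 (0.60 log units; beyond the scatter) here. The smaller edit points the same way, since carbamoyl in place of methyl on a saturated chain carbon bound to an amine nitrogen gives a 3.2-fold higher number from compound 1 to compound 3 (0.50 log units; beyond the scatter) in this comparison, so the weakening appears against both of the other amines. Nothing measured here accounts for this weakening. From the compounds shown here alone, how a carboxylic acid or a hydroxyl group in place of the carbamoyl would read at this carbon remains open. So does the standing of a ring amine such as piperidine at the end of the chain, or of a longer chain carrying the same carbamoyl group.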